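From methyl to chloro on the sulfonyl aromatic ring

The source may hold more compounds than are shown below. What is called first, only, known or untested is meant among the compounds shown, and "the series" means these compounds.

Of the compounds shown here, three have been measured so far in a functional assay on QGY-7703 cells (Homo sapiens) for cytotoxicity, read by MTT assay, with a stated time of 24 h (a lower number here means a stronger inhibitor, a higher number a weaker inhibitor), on the same scale. Compound 1 (`COc1cc(/C=C2\CN(C)C/C(=C\c3cccnc3)C2=O)cc(OC)c1`) gives 7900 nM there, compound 2 (`CN1C/C(=C\c2cccnc2)C(=O)/C(=C/c2ccccc2F)C1`) gives 4470 nM and compound 3 (`Cc1ccc(S(=O)(=O)N2C/C(=C\c3cccnc3)C(=O)/C(=C/c3ccccc3F)C2)cc1`) gives 9700 nM in the same read-out. Compound 3 lies within the scatter of compound 1 and beyond the scatter above compound 2.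

Compound 4 (`O=C1/C(=C/c2cccnc2)CN(S(=O)(=O)c2ccc(Cl)cc2)C/C1=C\c1ccccc1F`) differs from compound 3 by chloro in place of methyl on an aromatic carbon and carries chloro in place of methyl on an aromatic carbon, para to a large group. For the measured compounds named here, only one measured step bears on this, and only indirectly: a 2.2-fold higher number from compound 2 to compound 3 (0.34 log units; beyond the scatter) when (4-methylphenyl)sulfonyl replaces methyl on the amine nitrogen in the ring. Going by the values given here, that step is modest, and no measured step covers a swap on the aromatic ring itself, so no direction is firm. Expected in this assay is no step beyond the scatter, with the estimate being a 1.2-fold lower number from compound 3 to compound 4 (0.08 log units; within the scatter) and nothing larger foreseen. For compound 4 the estimated value is 8000 nM with an expected range from 3800 nM to 17000 nM overall.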

Compound 4, half-maximal inhibitory concentration: 12100 nM
The estimate for compound 4 lay 1.5-fold (0.18 log units) below the measured number; measured number inside the range.
By their numbers in this assay, from the lowest: compounds 2, 1, 3 and 4 (each within the scatter of the next, the first and the last beyond it).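

In this assay, for the compounds shown here, the swap of chloro in place of methyl on an aromatic carbon, para to a large group, is the first measured change on this ring (a 1.2-fold higher number from compound 3 to compound 4 (0.10 log units; within the scatter)), so the two groups cannot be told apart at this place. The step from the methyl on the ring amine nitrogen also stays beyond the scatter with the chloro-bearing group (a 2.7-fold higher number from compound 2 to compound 4 (0.43 log units; beyond the scatter)), and it points the same way as the earlier step with the methyl-bearing group (a 2.2-fold higher number from compound 2 to compound 3 (0.34 log units; beyond the scatter)). No supporting evidence is available to explain these numbers.

On these data alone, whether another group at this place, such as methoxy, a nitrile or an amine, would give a step beyond the scatter remains open. Also open, as far as these compounds go, is whether (4-chlorophenyl)sulfonyl on the amine nitrogen would act alike on the core of compound 1.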